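The compounds below may be only part of what the source reports. "The series", "measured", "known", "first", "only" and "open" are said of these compounds alone.

Compound 1 `COc1cc(C(F)(F)F)ccc1C(=O)NC1(c2ccccc2)CCCN(C)C1` in an assay on cells for inhibition of sodium- and chloride-dependent glycine transporter 1 (Homo sapiens) (on this read-out lower numbers stand for an effect already at smaller amounts and higher numbers for an effect only at larger amounts of compound), gives 4800 nM. Compound 2 `CN1CCCC(NC(=O)c2ccc(C(F)(F)F)cc2C#N)(c2ccccc2)C1` sits at the limit of this assay, > 10000 nM, which is a limit and not a number (the limit of > 10000 nM in this assay, at which 1 of the 2 values shown sits). Going by the values given here, the one measured step, an at least 2.0-fold higher number from compound 1 to compound 2 (0.31 log units; beyond the scatter), is thus a loss of unknown extent. Compound 3 `CN1CCCC(NC(=O)c2ccc(C(F)(F)F)cc2F)(c2ccccc2)C1` differs from compound 2 by fluoro in place of cyano on an aromatic carbon. Among the compounds with values here, no measured step covers a fluoro in this place, so the bearing is only that the cyano analogue reaches the limit while the methoxy analogue does not. Compound 3 is expected near 8000 nM (range 3000 nM to 25000 nM) in this assay. The expected step is an at least 1.2-fold lower number from compound 2 to compound 3 (0.09 log units; that floor lies within the scatter), with a fair chance that again only a limit is reported.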

Compound 3, half-maximal effective concentration: 9900 nM
Compound 3: middle estimate off by 1.2-fold (0.09 log units), on the low side; low and high end bracket the measured number.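

With fluoro in place of methoxy on the aromatic carbon, the series now has a measured size for a change at this position: a 2.1-fold higher number from compound 1 to compound 3 (0.31 log units; beyond the scatter). Of the groups with a readable value in this assay, methoxy gives the lower number. For fluoro in place of cyano the data give a number no higher from compound 2 to compound 3 (the limit leaves the size open) and no ranking of fluoro and cyano. Compound 2 carries a limit and not a number: the limit of > 10000 nM in this assay, at which 1 of the 3 values shown sits.

Open, from the compounds shown here alone, is whether a chlorine atom, a hydroxyl or an amine at this place would give a lower number than methoxy. Also open, going by these compounds, is whether the trifluoromethyl group contributes to these values at all.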